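The compounds below may be only part of what the source reports. "The series", "measured", "known", "first", "only" and "open" are said of these compounds alone.

Compound 1 `COc1cccc(Cc2cn(C3CC3)c3c(F)c(-c4cc(C)nc(C)c4)c(F)cc3c2=O)c1`: 20000 nM
Compound 2 `COc1ccccc1Cc1cn(C2CC2)c2c(F)c(-c3cc(C)nc(C)c3)c(F)cc2c1=O`: 37000 nM

In a functional assay on P388 cells (Mus musculus) for cytotoxicity (a higher number here means a weaker inhibitor, a lower number a stronger inhibitor), compound 2 gives 37000 nM, which stands level with compound 1 within the scatter. Compound 3 `Cc1cc(-c2c(F)cc3c(=O)c(Cc4ccc(O)cc4O)cn(C4CC4)c3c2F)cc(C)n1` carries a new group: 2,4-dihydroxyphenyl in place of 2-methoxyphenyl on a saturated chain carbon bound to an aromatic carbon. For the measured compounds named here, only one measured step bears on it, a 1.9-fold higher number from compound 1 to compound 2 (0.27 log units; within the scatter), and it involves no 2,4-dihydroxyphenyl group, so it offers only weak guidance. No step beyond the scatter is therefore expected in this assay, and no direction can be favoured. The expected step is a 1.5-fold lower number from compound 2 to compound 3 (0.17 log units; within the scatter). For compound 3, the estimated value is 25000 nM, with an expected range of 7000 nM to 80000 nM.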

Compound 3, half-maximal inhibitory concentration: 210 nM
Estimate against measurement, compound 3: 120-fold (2.08 log units) above, and the stated range ends above it.
By their numbers in this assay, from the lowest: compound 3; then compounds 1 and 2 (each within the scatter of the next).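

In this assay, the position on the saturated chain carbon bound to an aromatic carbon turns out to be highly sensitive to its substituent. Moving the methoxy group had left the numbers within the scatter, whereas 2,4-dihydroxyphenyl brings large gains over both 2-methoxyphenyl (a step of a 180-fold lower number from compound 2 to compound 3 (2.25 log units; beyond the scatter)) and 3-methoxyphenyl (a step of a 95-fold lower number from compound 1 to compound 3 (1.98 log units; beyond the scatter)). The compounds shown leave open whether both hydroxyl groups are needed, and whether a phenyl ring bearing a single hydroxyl or an amine would do the same. No evidence here gives a reason for the gain.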